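This account rests on a few compounds, and the source may have more. Where it says the series, first, only, none or still open, it means among the compounds named here.

Compound 1 `CC1(c2ccccc2)CC(=O)N(CC(=O)N2CCN(c3ccccc3Cl)CC2)C1=O`: "not active" (no number reported)
Compound 2 `COc1ccccc1N1CCN(C(=O)CN2C(=O)CC(C)(c3ccccc3)C2=O)CC1`: 100 mg/kg

Two compounds sharing one core were tested in a functional assay on the whole organism (strain CD-1) with Mus musculus as the target, in the maximal electroshock model, with a stated time of 0.5 h; a lower number here means that less compound is needed, a higher number that more compound is needed for the effect. Compound 1 gives "not active" (no number reported), so no number stands for it. Among the compounds with values here, compound 2 gives 100 mg/kg, which is the only number reported, and so compound 2 stands alone among the values shown; it cannot be ranked against compound 1 beyond noting that compound 1 produced no effect worth a number.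

Compound 3 `CC1(c2ccccc2)CC(=O)N(CC(=O)N2CCN(c3ccc(Cl)c(Cl)c3)CC2)C1=O` is the next compound, not yet measured. It differs from compound 2 in one place: 3,4-dichlorophenyl in place of 2-methoxyphenyl on an amine nitrogen in a ring. Within the data shown here, no step between two measured compounds is available to guide this change, and compound 1, which carries a chlorine on the same ring, gave no number at all. The expectation for compound 3 in this assay is therefore cautious: a step from compound 2 of about a 1.5-fold higher number from compound 2 to compound 3 (0.18 log units; within the scatter), that is, a shift of no great size toward a higher dose, with a real chance that no number will be reported. Compound 3 is estimated at 150 mg/kg, within a range from 60 mg/kg to 400 mg/kg.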

Compound 3, minimum effective dose: "not active" (no number reported)
Compound 3: no number reported, so the estimate cannot be set against anything.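

In this assay compound 3 gives "not active" (no number reported) while compound 2 gives 100 mg/kg and so no step can be read between them. Nothing shown here bears on this result. The compounds shown leave open whether any group other than 2-methoxyphenyl on the ring amine nitrogen would give a number in this assay at all.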